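The source may report more compounds than this note shows. Statements on the series, on what has been measured and on what is new or still open speak of the compounds shown alone.

Measured so far:
Compound 1 `CC(C)OC(=O)N1CCC(O[C@H]2CC[C@H](Oc3cnc(S(C)(=O)=O)cn3)CC2)CC1`: 120%
Compound 2 `CS(=O)(=O)c1cnc(O[C@H]2CC[C@H](OC3CCN(C(=O)OC4CCOC4)CC3)CC2)cn1`: 109%

In a functional assay on isolated protein for agonist activity at Glucose-dependent insulinotropic receptor (Rattus norvegicus), read by HTRF and cAMP accumulation (a lower number here means a smaller maximal response, a higher number a larger maximal response), compound 1 reaches 120%. Going by the values given here, compound 2 is the only other measured compound, and in this assay compound 2 reaches 109%, the lowest of the two numbers; its nearest neighbour is compound 1, and the gap is the single measured step, a number 11 percentage points lower from compound 1 to compound 2 (beyond the scatter), which lies beyond the scatter but is modest in size.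

The next compound, compound 3 `CS(=O)(=O)c1cnc(O[C@H]2CC[C@H](OC3CCN(C(=O)C4(C(F)(F)F)CCCC4)CC3)CC2)cn1`, is not yet measured. It differs from compound 2 in one place: a group of 9 heavy atoms (6 carbon, 3 fluorine; one five-membered non-aromatic ring of carbon only) in place of a group of 6 heavy atoms (4 carbon, 2 oxygen; one five-membered non-aromatic ring with 1 hetero atom), on a carbonyl carbon

Among the compounds with values here, the only measured step, a number 11 percentage points lower from compound 1 to compound 2 (beyond the scatter), concerns a different position, the oxygen next to the carbonyl group, and shows that exchanging a group there shifted the maximal response by a modest amount. Within the data shown here, no measured step covers an exchange on the carbonyl carbon itself, so the direction of the change from compound 2 to compound 3 cannot be read from the data. An estimated step of a number 4 percentage points lower from compound 2 to compound 3 (within the scatter), essentially within the scatter, is therefore expected. Compound 3 is estimated to reach 105%, in the range 85% to 125%.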

Compound 3, largest response reached (Emax), in percent of the reference or control that the assay uses: 124%
Estimate against measurement, compound 3: 19 percentage points below; measured number inside the range.
By their numbers in this assay, from the lowest: compound 2; then compounds 1 and 3 (each within the scatter of the next).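

In this assay the position on the carbonyl carbon, whose other neighbour is the amide-type nitrogen in a ring, proves responsive to exchange: a number 15 percentage points higher from compound 2 to compound 3 (beyond the scatter), as the (oxolan-3-yl)oxy group, with its 2 hydrogen-bond acceptors, gives way to a group of 9 heavy atoms with none. An oxygen attached to this carbonyl carbon is also not needed to keep the maximal response of the isopropyl-bearing compound, since the step is a number 4 percentage points higher from compound 1 to compound 3 (within the scatter), and the two compounds cannot be told apart in this measurement. Nothing available explains why the maximal response moves with this exchange.

The compounds shown leave open whether the trifluoromethyl group or the carbon-only five-membered ring accounts for the step, as the two enter together and neither appears here alone. A plain methyl in place of the trifluoromethyl, a six-membered carbon ring in place of the five-membered one, or an amine on the carbonyl carbon would each separate these contributions.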